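Three Sulfur-Bearing Analogues and an Untested Fourth

The compounds below may be only part of what the source reports. "The series", "measured", "known", "first", "only" and "open" are said of these compounds alone.

Of the compounds shown here, three of a shared core have been tested in a functional assay on the whole organism for inhibition, with Mus musculus as the target, at a dose of 10 mg/kg by the oral route; a lower number here means less inhibition, a higher number more inhibition at the dose given (going by the name of the read-out). Compound 1 `CSc1ccc2c(c1)c(O)c(C(=S)N(C)c1ccccc1)c(=O)n2C` gives 32%. Compound 2 `Cc1ccc2c(c1)C(=O)/C(=C(\S)N(C)c1ccccc1)C(=O)N2C` gives 20%. Compound 3 `COc1cccc(N(C)/C(S)=C2/C(=O)c3cc(Cl)ccc3N(C)C2=O)c1` gives 30%. Among the compounds with values here, compound 3 lies within the usual scatter of both compound 1 and compound 2, so the three numbers cannot be told apart with confidence, and no compound among them can be called stronger or weaker than another.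

Compound 4 `CN1C(=O)/C(=C(/S)N(C)c2ccc(Cl)cc2)C(=O)c2cc(Cl)ccc21` has not yet been measured. It differs from compound 3 in one place: 4-chlorophenyl in place of 3-methoxyphenyl on an amine nitrogen. Within the data shown here, no pair of measured compounds differs by a single change of this kind, so there is no measured step to lean on.

Since compound 3 gives 30% and every measured number sits inside the scatter of every other, the expected step in this assay is none beyond the scatter, which is what no change at the digits printed from compound 3 to compound 4 (within the scatter) means as an estimate. Compound 4 is accordingly expected to give about 30% in this assay, with the estimate spanning from 15% to 45%.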

Compound 4, a percentage reported as inhibition, in the whole organism at one dose (the size of the read-out at that dose, not a potency): 47%
The estimate for compound 4 lay 17 percentage points below the measured number; measured number outside the range, above it.
By their numbers in this assay, from the lowest: compounds 2, 3 and 1 (each within the scatter of the next, the first and the last beyond it); then compound 4.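

Under this assay the change of 3-methoxyphenyl to 4-chlorophenyl on the amine nitrogen gives a number 17 percentage points higher from compound 3 to compound 4 (beyond the scatter) and so provides the first single-change comparison in this set. Within the data shown here, it shows that the group at this position can alter the inhibition read at this one dose, which the earlier compounds could not show, since no two of them differed in only one place. The data offer no explanation for this step.

This single step changes both the atoms attached to the aromatic ring and the number in the group's name, so it cannot say which of the two matters; 4-methoxyphenyl and 3-chlorophenyl on the same nitrogen would separate them. A pyridine ring in this place would show whether the all-carbon aromatic ring shared by both groups is needed.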